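Sulfamate series: piperidine replaces the ethyl pyridylmethyl amine

This account rests on a few compounds, and the source may have more. Where it says the series, first, only, none or still open, it means among the compounds named here.

Three sulfamate amides have been measured in an assay on HEK293 cells for inhibition of Steryl-sulfatase (Homo sapiens), tested at 0.1 uM; on this read-out higher numbers stand for a stronger effect at the one concentration tested and lower numbers for a weaker effect. Compound 1 `CCN(Cc1ccc(Br)cc1)c1cccc(C(=O)N2CCc3ccc(OS(N)(=O)=O)cc3C2)c1` gives 24.2%. Compound 2 `NS(=O)(=O)Oc1ccc2c(c1)CN(C(=O)c1ccc(N3CCC(N4CCCCC4)CC3)cc1)CC2` gives 8.5%. Compound 3 `CCN(Cc1cccnc1)c1ccc(C(=O)N2CCc3ccc(OS(N)(=O)=O)cc3C2)cc1` gives 35.7%, the highest of the three numbers; compound 1 is nearest and compound 2 furthest, both beyond the scatter. Compound 4 `NS(=O)(=O)Oc1ccc2c(c1)CN(C(=O)c1ccc(N3CCCCC3)cc1)CC2` is the next compound; it differs from compound 3 by piperidin-1-yl in place of ethyl((pyridin-3-yl)methyl)amino on an aromatic carbon. Going by the values given here, no measured pair shows this change on its own, so the expected step rests on the values shown. The expected downward step in this assay is a number 21.7 percentage points lower from compound 3 to compound 4 (beyond the scatter) because compound 2 gives 8.5%. Compound 4 is estimated at 14%, within 3% to 30%.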

Compound 4, a percentage reported as inhibition, at one concentration (the size of the read-out at that concentration, not a potency): 11.5%
Estimate against measurement, compound 4: 2.5 percentage points above; measured number inside the range.
By their numbers in this assay, from the lowest: compounds 2 and 4 (each within the scatter of the next); then compound 1; then compound 3.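

In this assay the change to piperidin-1-yl on this aromatic carbon, para to a large group, gives a number 24.2 percentage points lower from compound 3 to compound 4 (beyond the scatter) and so the ethyl((pyridin-3-yl)methyl)amino group holds the higher number of this pair. Hydrogen in place of piperidin-1-yl on the saturated ring carbon gives a number 3 percentage points higher from compound 2 to compound 4 (within the scatter) and so this outer ring does not separate the two compounds. Nothing shown gives a reason for either step.

Open, going by these compounds, is which part of ethyl((pyridin-3-yl)methyl)amino carries the step, and whether a morpholine ring or a dimethylamino group on this carbon would fall with compound 3 or with compound 4.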